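A few compounds are considered here, and "the series" means these few. Any claim that something is new, unique, unknown or untested is made for them only; others in the source may bear on it.

For the measured compounds named here, the two cinnamoyl compounds measured so far share the same double-bonded chain and phenyl group and differ only in what hangs on the carbonyl. Compound 1 `O=C(/C=C/c1ccccc1)NCc1ccc(Cl)cc1Cl` carries an amide to a dichlorobenzyl group, and in a functional assay on the whole organism for inhibition, with Brassica rapa subsp. chinensis as the target, with a stated time of 3 days, tested at 100 ppm (on this read-out lower numbers stand for less inhibition of growth and higher numbers for more inhibition of growth at the one concentration tested), compound 1 gives 43%. Compound 2 `CCC(C)OC(=O)/C=C/c1ccccc1` is the sec-butyl ester, and in this assay compound 2 gives 20%, the lower of the two numbers, with compound 1 standing higher by a margin beyond the usual scatter. Going by the values given here, since the two differ in more than one place, their pair tells only that the amide compound came out the more inhibitory of the two.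

Compound 3 `C=CCNC(=O)/C=C/c1ccccc1` keeps the core of compound 2 and changes one place: allylamino in place of sec-butoxy on a carbonyl carbon. Among the compounds with values here, no single-change step between measured compounds is available to calibrate this exchange. Because compound 1, the other amide, gives 43%, a rise in this assay from compound 2 to compound 3 of moderate size, somewhat beyond the scatter, is expected, amounting to a number 15 percentage points higher from compound 2 to compound 3 (beyond the scatter). For compound 3 the expected growth inhibition is 35%, with a range from 15% to 60%.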

Compound 3, percent growth inhibition at one concentration: 64%
For compound 3 the middle estimate is 29 percentage points below the measured one; measured number above the stated range.
By their numbers in this assay, from the lowest: compound 2; then compound 1; then compound 3.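

For the compounds shown here, the exchange of sec-butoxy for allylamino on a carbonyl carbon is the first single-place step in this set, and in this assay it gives a number 44 percentage points higher from compound 2 to compound 3 (beyond the scatter), showing that what hangs on this carbonyl can by itself change the growth inhibition by a large amount. The exchange alters more than one feature at once: the ester oxygen gives way to an amide nitrogen, a hydrogen-bond donor enters, and the incoming chain brings a double bond outside aromatic rings, so this one step cannot assign its size to any of these features. Nothing available bears on why the number rises so far with this change.

Still open, from the compounds shown here alone, is whether the linking nitrogen or the allyl chain carries the step, a question that an allyloxy group, or a propylamino group with its saturated chain, on the same carbonyl would help to separate. Also open, going by these compounds, is how the amide series continues beyond the two groups on nitrogen seen here, for instance with a plain unsubstituted amide or a longer chain such as n-hexylamino.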